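From morpholin-4-yl to 2,6-dimethylmorpholin-4-yl on compound 3

A few compounds are considered here, and "the series" means these few. Any claim that something is new, unique, unknown or untested is made for them only; others in the source may bear on it.

The series is read in a functional assay on MDA-MB-231 cells (Homo sapiens) for inhibition, read by MTT assay, with a stated time of 48 h; on this read-out lower numbers stand for stronger inhibition and higher numbers for weaker inhibition. Compound 1 (`Cn1c(/C=C2\SC(=O)N(CC(=O)N3CCOCC3)C2=O)nc2ccccc21`) reports only a limit, > 50000 nM. Compound 3 (`CC(C)n1c(/C=C2\SC(=O)N(CC(=O)N3CCOCC3)C2=O)nc2ccccc21`) also reports only a limit, > 50000 nM. Compound 2 (`Cn1c(/C=C2\SC(=O)N(CC(=O)Nc3nc(-c4ccccc4)cs3)C2=O)nc2ccccc21`) is the only one of the three with a number, 29200 nM. Compound 3 thus stands at the limit of > 50000 nM in this assay, at which 2 of the 3 values shown sit.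

Compound 4 (`CC1CN(C(=O)CN2C(=O)S/C(=C\c3nc4ccccc4n3C(C)C)C2=O)CC(C)O1`) carries 2,6-dimethylmorpholin-4-yl in place of morpholin-4-yl on a carbonyl carbon. For the measured compounds named here, the only measured step, a step that the two limits leave unreadable from compound 1 to compound 3, lies at another place and gives no size to carry over. The expectation therefore rests on compound 3, whose > 50000 nM is a limit. No step beyond the scatter is expected in this assay, and the expected at least 1.1-fold lower number from compound 3 to compound 4 (0.04 log units; that floor lies within the scatter) remains a rough figure with no firm direction. Compound 4 is estimated at 45000 nM, with an expected range of 20000 nM to 100000 nM, and it may well report only a limit again.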

Compound 4, half-maximal inhibitory concentration: > 50000 nM
Compound 4 was reported as a limit; the forecaster's own chance of this, stated with the estimate: 60%; at least 1.1-fold (0.04 log units) between middle value and limit.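

Compound 4 reports only a limit, > 50000 nM, as compound 3 does, so the step between these two compounds cannot be read. The compounds shown leave open how morpholin-4-yl and 2,6-dimethylmorpholin-4-yl compare in this assay, where most values sit at one limit: the limit of > 50000 nM in this assay, at which 3 of the 4 values shown sit.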